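Swapping a Fluorophenyl Ring for a Methoxypyridine

The source may report more compounds than this note shows. Statements on the series, on what has been measured and on what is new or still open speak of the compounds shown alone.

Measured compounds in an in vitro functional assay on HEK285-7 cells for antagonist activity at prostaglandin D2 receptor 2 (Homo sapiens), read by BRET and beta-arrestin recruitment; a higher number here means a weaker inhibitor, a lower number a stronger inhibitor:
Compound 1, `O=C(O)Cc1sc(CSc2ccccc2)nc1-c1ccc(Cl)cc1`, gives 450 nM.
Compound 2, `O=C(O)Cc1sc(C(Cc2ccccc2)c2ccccc2)nc1-c1ccc(Cl)cc1`, gives 510 nM.
Compound 3, `O=C(O)Cc1sc(C(c2ccc(F)cc2)c2ccc(F)cc2)nc1-c1cccc(F)c1`, gives 18 nM.

Compound 3 has the lowest number of the three, and both other compounds sit beyond the scatter above it, so compound 3 is the strongest inhibitor among them. Compound 4, `COc1cc(-c2nc(C(c3ccc(F)cc3)c3ccc(F)cc3)sc2CC(=O)O)ccn1`, differs from compound 3 in one place: 2-methoxypyridin-4-yl in place of 3-fluorophenyl on an aromatic carbon. Among the measured compounds shown here, no measured pair shows what this kind of change does, so there is no step to lean on. The expected step of a 1.4-fold higher number from compound 3 to compound 4 (0.14 log units; within the scatter) is small, staying within the usual scatter rather than pointing clearly in either direction. Compound 4 is therefore expected to give about 25 nM in this assay, with a range from 8 nM to 80 nM.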

Compound 4, half-maximal inhibitory concentration: 380 nM
The estimate for compound 4 lay 15-fold (1.18 log units) below the measured number, outside the stated range (above it).
By their numbers in this assay, from the lowest: compound 3; then compounds 4, 1 and 2 (each within the scatter of the next).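

In this assay, 2-methoxypyridin-4-yl in place of 3-fluorophenyl on this aromatic carbon gives a 21-fold higher number from compound 3 to compound 4 (1.32 log units; beyond the scatter) and so shows that the two groups are not interchangeable at this position. Among the compounds shown here, this is the first pair differing in only one place, so it is the first direct reading of this position. Nothing at hand explains the size of this step. The methoxy group and the pyridine nitrogen enter together, and the compounds shown cannot separate them. On these data alone, how a plain pyridin-4-yl or a 3-methoxyphenyl would behave here remains open.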